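Methyl for Amino on a Sulfonyl Sulfur: Expected Half-Life

The compounds below may be only part of what the source reports. "The series", "measured", "known", "first", "only" and "open" are said of these compounds alone.

Of the compounds shown here, three sharing one core have been measured in an ADME assay on isolated protein for pharmacokinetics, with UDP-glucuronosyltransferase 1A9 (Homo sapiens) as the target, read by LC-MS, with a stated time of 60 min, at 37 degrees C, tested at 1 uM, in the presence of a further agent that is not named here; a lower number here means that the compound disappears faster, a higher number that the compound lasts longer. Compound 1, `NS(=O)(=O)CC(=O)NCCSc1nonc1/C(=N/O)Nc1cccc(C(F)F)c1`, gives > 3 h, which is a limit of the assay rather than a number. Compound 3, `CS(=O)(=O)CC(=O)NCCSc1nonc1/C(=N/O)Nc1ccc(F)c(C(F)F)c1`, gives 1.59 h. Compound 2, `NS(=O)(=O)NCCSc1nonc1/C(=N/O)Nc1ccc(F)c(Br)c1`, gives 0.183 h, the lowest of the two numbers shown; compound 3 stands higher by a gap beyond the usual scatter, but the two differ in more than one place, so no single change can be read from them.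

Compound 4, `CS(=O)(=O)NCCSc1nonc1/C(=N/O)Nc1ccc(F)c(Br)c1`, has not yet been measured. It differs from compound 2 in one place: methyl in place of amino on a sulfonyl sulfur. Within the data shown here, no pair of measured compounds differs by exactly this change, so its effect on half-life has no direct precedent here. The methylsulfonyl group of compound 4 also appears in compound 3, and the sulfamoyl group of compound 2 appears in compound 1, yet each of those pairs differs further in the chain and the ring substituents, so they set no expectation on their own. A modest shift is expected, most likely within the scatter, with a slight lean upward. Compound 4 is therefore estimated at 0.3 h in this assay, with a range from 0.1 h to 1 h. The expected step from compound 2 to compound 4 is a 1.6-fold higher number from compound 2 to compound 4 (0.21 log units; within the scatter).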

Compound 4, half-life: 0.357 h
Estimate against measurement, compound 4: 1.2-fold (0.08 log units) below; the range from low to high includes it.
By their numbers in this assay, from the lowest: compounds 2 and 4 (each within the scatter of the next); then compound 3. At a limit, above all of these: compound 1.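

Among these compounds, with the rest of compound 2 held fixed, replacing amino with methyl on a sulfonyl sulfur gives a 2.0-fold higher number from compound 2 to compound 4 (0.29 log units; within the scatter) in this assay, the first direct reading of this change. The two compounds therefore cannot be told apart by their half-lives, even though the change removes one hydrogen-bond donor from this position. Among the compounds shown here, compound 1 and compound 3 also carry these two sulfonyl groups, but they differ from each other in more than one place, so only this new pair isolates the change.

From the compounds shown here alone, it remains open whether the same replacement would give a similar result on the chain shared by compound 1 and compound 3, or with the ring substituents found there, and what an ethyl group or a cyclopropyl ring would do on the same sulfur. Compound 1 is also a limit of the assay and not a number, so its true half-life cannot be placed on the same scale as the others: the limit of > 3 h in this assay, at which 1 of the 4 values shown sits.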